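Replacing the nitrile on the ring-amine side chain

The source may hold more compounds than are shown below. What is called first, only, known or untested is meant among the compounds shown, and "the series" means these compounds.

Measured compounds:
Compound 1 `COc1c(N2CCN(CC#N)C(C)C2)c(F)cc2c(=O)c(C(=O)O)cn(C3CC3)c12`: 354 ug/mL
Compound 2 `CCOC(=O)CN1CCN(c2c(F)cc3c(=O)c(C(=O)O)cn(C4CC4)c3c2OC)CC1C`: 1000 ug/mL

In an ADME assay on Vero cells (Chlorocebus sabaeus) for cytotoxicity, read by MTT assay, with a stated time of 72 h (a higher number here means that more compound is tolerated, a lower number that less compound is tolerated), compound 1 gives 354 ug/mL, the lowest of the two numbers. Its nearest neighbour is compound 2, which in this assay gives 1000 ug/mL; the step of a 2.8-fold higher number from compound 1 to compound 2 (0.45 log units; beyond the scatter) is the only one measured so far, and it came from putting ethoxycarbonyl in place of cyano on a saturated chain carbon bound to an amine nitrogen in a ring.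

Compound 3 `COc1c(N2CCN(C/C(C)=N/O)C(C)C2)c(F)cc2c(=O)c(C(=O)O)cn(C3CC3)c12` has not yet been measured. It differs from compound 1 in one place: a group of 4 heavy atoms (2 carbon, 1 nitrogen, 1 oxygen; no ring) in place of a group of 2 heavy atoms (1 carbon, 1 nitrogen; no ring), on a saturated chain carbon bound to an amine nitrogen in a ring. The same cyano leaves as in the step to compound 2, but a different group enters, so that step is only a loose guide. A small rise, or no change beyond the scatter, is the expectation. Compound 3 is therefore estimated to give about 500 ug/mL in this assay, between 250 ug/mL and 1000 ug/mL, an expected step of a 1.4-fold higher number from compound 1 to compound 3 (0.15 log units; within the scatter).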

Compound 3, half-maximal cytotoxic concentration: 177 ug/mL
For compound 3 the middle estimate is 2.8-fold (0.45 log units) above the measured one; the measured number lies below the stated range.
By their numbers in this assay, from the lowest: compounds 3 and 1 (each within the scatter of the next); then compound 2.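

At this saturated chain carbon bound to an amine nitrogen in a ring, replacing cyano with the group of 4 heavy atoms, which carries 1 hydrogen-bond donor, gives a 2.0-fold lower number from compound 1 to compound 3 (0.30 log units; within the scatter) in this assay, so this change does not clearly separate the two compounds. Losing cyano is therefore not enough on its own to give the higher number seen with ethoxycarbonyl. The entering group matters, as the comparison of the two replacements shows: a 5.6-fold lower number from compound 2 to compound 3 (0.75 log units; beyond the scatter) is a real difference.

On these data alone, it remains open whether that higher number belongs to ethoxycarbonyl in particular, which a carboxylic acid, a primary amide or a longer ester chain on the same carbon could test. No measurement offered here explains why these groups differ.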